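Swapping a Methylfuran for a Methylphenyl on a Weak Compound

The source may hold more compounds than are shown below. What is called first, only, known or untested is meant among the compounds shown, and "the series" means these compounds.

The measured compounds:
compound 1, `Clc1ccc(-c2cc(-c3cccs3)nc(-c3ccccc3Cl)c2)o1`, 6190 nM in a functional assay on HCT-15 cells (Homo sapiens) for cytotoxicity, in the presence of a further agent that is not named here; a higher number here means a weaker inhibitor, a lower number a stronger inhibitor
compound 2, `Clc1ccc(-c2cc(-c3cccnc3)nc(-c3cccs3)c2)o1`, 1240 nM
compound 3, `Cc1ccc(-c2cc(-c3ccc(Cl)o3)cc(-c3ccsc3)n2)o1`, > 50000 nM

Compound 3 stands at a limit of this assay and not at a number: the value > 50000 nM is the boundary of what the measurement reports, and the limit of > 50000 nM in this assay, at which 1 of the 3 values shown sits, records this. Going by the values given here, compound 1 and compound 2 both give numbers, and the one measured step between them, a 5.0-fold lower number from compound 1 to compound 2 (0.70 log units; beyond the scatter), concerns a change at another position and a different pair of groups.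

Compound 4, `Cc1ccc(-c2cc(-c3ccc(Cl)o3)cc(-c3ccsc3)n2)cc1`, differs from compound 3 by 4-methylphenyl in place of 5-methylfuran-2-yl on an aromatic carbon. Among the compounds with values here, no measured step covers this exchange, so the only anchor is the limit at which compound 3 sits. The 5-methylfuran-2-yl group leaves and the 4-methylphenyl group enters; the data hold nothing that would set the direction of the change. Compound 4 is therefore expected to remain near the limit, and the step of a number no higher from compound 3 to compound 4 (the limit leaves the size open) is estimated to stay within the scatter. Compound 4 is estimated at 50000 nM, with a range from 12000 nM to 200000 nM, and a strong chance that this assay again reports only a limit.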

Compound 4, half-maximal inhibitory concentration: 7410 nM
Compound 4: the middle estimate sits 6.7-fold (0.83 log units) above what was measured; measured number below the stated range.
By their numbers in this assay, from the lowest: compound 2; then compounds 1 and 4 (each within the scatter of the next). At a limit, above all of these: compound 3.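

The exchange of 5-methylfuran-2-yl for 4-methylphenyl, on the aromatic carbon next to the ring nitrogen, gives an at least 6.7-fold lower number from compound 3 to compound 4 (0.82 log units; beyond the scatter) in this assay. Going by these compounds alone, this is the first sign that this position responds to the group it carries, and the direction runs towards the 4-methylphenyl group, with compound 4 giving 7410 nM. Compound 3 holds a limit, > 50000 nM, and not a number, so the step sets only a floor for the size of the change: the limit of > 50000 nM in this assay, at which 1 of the 4 values shown sits.

From the compounds shown here alone, whether the change follows from the six-membered aromatic ring of carbon only, or from the way that ring holds its methyl group, stays open. The compounds shown also do not tell how a plain phenyl ring, or one carrying an amine or a carboxylic acid, would read at this position.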